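From Benzamide to Cinnamamide on a Shared Core

The source may hold more compounds than are shown below. What is called first, only, known or untested is meant among the compounds shown, and "the series" means these compounds.

Compound 1 `CCc1ccc(C(=O)NC[C@H]2c3[nH]c4ccccc4c3C[C@H]3[C@H]4c5[nH]c6ccccc6c5C[C@@H]([C@H](C#N)N23)N4C)cc1` and compound 2 `CN1[C@@H]2c3[nH]c4ccccc4c3C[C@H]1[C@H](C#N)N1[C@@H](CNC(=O)/C=C/c3cccc(C(F)(F)F)c3)c3[nH]c4ccccc4c3C[C@@H]21` share one core and differ only in the group attached to the amide carbonyl carbon. In a functional assay on HT-29 cells (Homo sapiens) for cytotoxicity, read by MTT assay, with a stated time of 72 h (a lower number here means a stronger inhibitor, a higher number a weaker inhibitor), compound 1 gives 3560 nM, and compound 2 gives 5060 nM. Among the measured compounds shown here, compound 1 has the lowest of the two numbers seen so far, but its only neighbour, compound 2, sits within the scatter: a 1.4-fold higher number from compound 1 to compound 2 (0.15 log units; within the scatter). Compound 3 `CN1[C@@H]2c3[nH]c4ccccc4c3C[C@H]1[C@H](C#N)N1[C@@H](CNC(=O)/C=C/c3ccccc3)c3[nH]c4ccccc4c3C[C@@H]21` has not been measured yet. It differs from compound 1 as follows: 2-phenylethenyl in place of 4-ethylphenyl on a carbonyl carbon. For the measured compounds named here, the one measured step that bears on this change is the step from compound 1 to compound 2, in which 2-(3-(trifluoromethyl)phenyl)ethenyl took the place of 4-ethylphenyl on the same carbonyl carbon, and that step stayed within the scatter. On that basis the step of a 1.3-fold higher number from compound 1 to compound 3 (0.10 log units; within the scatter) is expected to stay within the scatter as well. The estimate for compound 3 is therefore 4500 nM, with a range from 2000 nM to 10000 nM.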

Compound 3, half-maximal inhibitory concentration: 1400 nM
Compound 3: the middle estimate sits 3.2-fold (0.51 log units) above what was measured, outside the stated range (below it).
By their numbers in this assay, from the lowest: compound 3; then compounds 1 and 2 (each within the scatter of the next).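

In this assay the 2-phenylethenyl group on the carbonyl carbon gives a 2.5-fold lower number from compound 1 to compound 3 (0.41 log units; beyond the scatter) when it replaces 4-ethylphenyl, so this position does respond to the change, which compound 2 alone could not show. Trifluoromethyl on the aromatic ring turns out to matter as well: hydrogen in its place gives a 3.6-fold lower number from compound 2 to compound 3 (0.56 log units; beyond the scatter) and makes compound 3 the strongest of the three, whereas compound 2 stays within the scatter of compound 1. Nothing measured here explains why these numbers move.

As far as these compounds go, whether a methoxy group or a chlorine atom on that aromatic ring would behave like hydrogen or like trifluoromethyl remains open. So does the role of the double bond outside the aromatic ring, which a 2-phenylethyl group in place of 2-phenylethenyl would address.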